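A few compounds are considered here, and "the series" means these few. Any claim that something is new, unique, unknown or untested is made for them only; others in the source may bear on it.

Compound 1 `CCOC(=O)c1ccc(NC(=O)NCc2ccnnc2)cc1` was tested in an assay on isolated protein for activation of Nicotinamide phosphoribosyltransferase (Homo sapiens) (a higher number here means that more compound is needed for the effect, a lower number that less compound is needed), and gave only a limit, > 100000 nM. For compound 1 this is the limit of > 100000 nM in this assay, at which 1 of the 3 values shown sits. Two other compounds with the shared core carry a sulfonamide in place of the ester: compound 2 `CN(Cc1ccccc1)S(=O)(=O)c1ccc(NC(=O)NCc2ccncc2)cc1` gives 23 nM in this assay, and compound 3 `CCN(C1CCCC1)S(=O)(=O)c1ccc(NC(=O)NCc2ccncc2)cc1` gives 60 nM. Among the measured compounds shown here, the one measured step, a 2.6-fold higher number from compound 2 to compound 3 (0.42 log units; beyond the scatter), concerns the group on the sulfonyl sulfur and does not touch the heteroaryl. Compound 4 `CCOC(=O)c1ccc(NC(=O)NCc2c[nH]nn2)cc1` differs from compound 1 by 1H-1,2,3-triazol-4-yl in place of pyridazin-4-yl on a saturated chain carbon bound to an amide-type nitrogen. For the measured compounds named here, no measured step bears on this change, and compound 1 has no number to start from. Compound 4 is therefore expected to remain near the limit, with a step that the limit leaves unreadable from compound 1 to compound 4 estimated as no real movement. Compound 4 is estimated at 150000 nM, between 30000 nM and 1000000 nM.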

Compound 4, half-maximal effective concentration: 7750 nM
Beside the measured number, compound 4's estimate is 19-fold (1.29 log units) above it, outside the stated range (below it).
By their numbers in this assay, from the lowest: compound 2; then compound 3; then compound 4. At a limit, above all of these: compound 1.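

The group on the saturated chain carbon bound to an amide-type nitrogen now proves able to move the result with the ester in place: 1H-1,2,3-triazol-4-yl in place of pyridazin-4-yl gives an at least 12-fold lower number from compound 1 to compound 4 (1.11 log units; beyond the scatter). Compound 1 stands at a limit and not a number, so this step has only a lower bound: the limit of > 100000 nM in this assay, at which 1 of the 4 values shown sits.

The compounds shown leave open whether this change would carry over to a sulfonamide such as compound 2. They also leave open how a carboxylic acid in place of the ethyl ester, or 1H-pyrazol-4-yl at this position, would read in this assay.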